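The source may hold more compounds than are shown below. What is called first, only, known or untested is meant among the compounds shown, and "the series" means these compounds.

Of the compounds shown here, two have so far been measured in an ADME assay on MT2 cells (Homo sapiens) for cytotoxicity; on this read-out lower numbers stand for higher toxicity in this test and higher numbers for lower toxicity in this test. Compound 1 `COc1ccnc(Nc2ccc(C#N)c(OCC=C(C)C)c2)n1` gives 230 nM, while compound 2 `CC(C)=CCOc1cc(Nc2nccc(N)n2)ccc1C#N` gives 41 nM. Among the measured compounds shown here, the single measured step, a 5.6-fold lower number from compound 1 to compound 2 (0.75 log units; beyond the scatter), shows that amino in place of methoxy on an aromatic carbon brings a modest move to a lower number. Compound 2 thus stands at the lower of the two numbers, beyond the scatter from compound 1.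

Compound 3 `CNc1ccnc(Nc2ccc(C#N)c(OCC=C(C)C)c2)n1` has not yet been measured; it differs from compound 2 by methyl in place of hydrogen on a nitrogen on an aromatic ring. For the measured compounds named here, no measured step tests this exact change; the only step touching this position is the one from methoxy to amino, and it was modest. The methyl brings the group partway back toward the methoxy of compound 1, which in this assay gave 230 nM. A modest move to a higher number is therefore expected: a 2.2-fold higher number from compound 2 to compound 3 (0.34 log units; beyond the scatter). Compound 3 is estimated at 90 nM, with a range of 30 nM to 250 nM.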

Compound 3, half-maximal cytotoxic concentration: 22 nM
For compound 3 the middle estimate is 4.1-fold (0.61 log units) above the measured one; measured number below the stated range.
By their numbers in this assay, from the lowest: compounds 3 and 2 (each within the scatter of the next); then compound 1.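

In this assay, methyl in place of hydrogen on this nitrogen gives a 1.9-fold lower number from compound 2 to compound 3 (0.27 log units; within the scatter) and so does not separate the methylamino group from the amino group, nor does it lead back toward the methoxy group. Methylamino in place of methoxy on the same aromatic carbon gives a 10-fold lower number from compound 1 to compound 3 (1.02 log units; beyond the scatter) as a large step, so among these three compounds, both groups attached through nitrogen stand apart from the one attached through oxygen. Nothing available explains this result.

The compounds shown leave open whether a longer chain on this nitrogen, such as ethyl, or a second methyl, as in dimethylamino, would stay with compound 2 and compound 3. They also leave open where a hydroxyl group on this aromatic carbon would fall.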